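Removal of tert-butoxycarbonyl on the chain, second instance

This account rests on a few compounds, and the source may have more. Where it says the series, first, only, none or still open, it means among the compounds named here.

Measured compounds:
compound 1, `COC(=O)CC1c2ccccc2N=C(NCCCCCN)N1c1ccc(-c2ccccc2)cc1`, 560 nM
compound 2, `COC(=O)CC1c2ccccc2N=C(NCCCCCNC(=O)OC(C)(C)C)N1c1ccc(-c2ccccc2)cc1`, 680 nM
compound 3, `COC(=O)CC1c2ccccc2N=C(Nc2ccc(-c3ccccc3)cc2)N1CCCCCNC(=O)OC(C)(C)C`, 370 nM

All three were run in an assay on HEK293 cells for inhibition of Voltage-dependent T-type calcium channel subunit alpha-1G (Homo sapiens); on this read-out higher numbers stand for weaker inhibition and lower numbers for stronger inhibition. Going by the values given here, the one change measured twice in this set is hydrogen in place of tert-butoxycarbonyl on an amine nitrogen. Between compound 2 and compound 1 it gave a 1.2-fold lower number from compound 2 to compound 1 (0.08 log units; within the scatter), so on this read-out the two compounds are indistinguishable.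

Compound 3 is built from the same atoms as compound 2, joined differently; the difference between the two cores is not broken down here. The values of compound 2 and compound 3 in this assay lie within the scatter of each other, so nothing can be said about an order between them.

Compound 4, `COC(=O)CC1c2ccccc2N=C(Nc2ccc(-c3ccccc3)cc2)N1CCCCCN`, is not yet measured. It differs from compound 3 by hydrogen in place of tert-butoxycarbonyl on an amine nitrogen, at an amine nitrogen whose other neighbours are a saturated chain carbon, which is the same place as in the earlier pair; the change is therefore the same change, carried onto the core of compound 3.

The expectation rests on one pair only. Because the step of a 1.2-fold lower number from compound 2 to compound 1 (0.08 log units; within the scatter) lay within the scatter, the expected step from compound 3 to compound 4 is equally small, a 1.2-fold lower number from compound 3 to compound 4 (0.08 log units; within the scatter). Compound 4 is thus estimated at 310 nM in this assay, with a range of 150 nM to 650 nM, the width reflecting that the change has been seen on a single core whose value was 370 nM for compound 3 and that the cores differ in an uncounted way.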

Compound 4, half-maximal inhibitory concentration: 300 nM
For compound 4 the middle estimate is 1.0-fold (0.01 log units) above the measured one, and the stated range covers the measured number.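

In this assay, hydrogen in place of tert-butoxycarbonyl on the amine nitrogen of the chain gives a 1.2-fold lower number from compound 3 to compound 4 (0.09 log units; within the scatter), and on this read-out the two compounds stand within the scatter of each other. Set beside the earlier instance, the change behaves alike on the two cores, with no difference in step size that can be told apart from the noise of the measurement: the same change on two cores in this assay, a 1.2-fold lower number (0.08 log units; within the scatter) from compound 2 to compound 1 and a 1.2-fold lower number (0.09 log units; within the scatter) from compound 3 to compound 4, 1.0-fold (0.01 log units) apart, within the scatter of two such steps. Going by these compounds alone, this shows only that the terminal group on the chain can be exchanged in this way on either core without a measurable shift; it does not show that the change has an effect of any size, since neither step stands clear of the scatter, and two cores give no basis for a rule across the wider series.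

The compounds shown leave open whether the chain itself matters, as a shorter or a longer chain would test, and whether a terminal group other than the free amine or tert-butoxycarbonyl, such as an acetamide or a dimethylamine, would shift the number beyond the scatter. They also leave open what a carboxylic acid in place of the methyl ester would do on either core.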